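The source may report more compounds than this note shows. Statements on the series, on what has been measured and on what is new or still open speak of the compounds shown alone.

In an assay on LX2 cells for inhibition of COL1A1 promoter (Homo sapiens), read by a luciferase reporter, with a stated time of 24 h, tested at 50 uM (on this read-out lower numbers stand for a weaker effect and higher numbers for a stronger effect at the one concentration tested), compound 1 `CC[N+]1(CCCCCCCOc2ccc(-n3cc(C(=O)Nc4cc(F)cc(F)c4)c(=O)c4ccc(N(C)C)nc43)cc2Cl)CCCCC1` gives 50.4%, and compound 3 `CN1CC[N+](C)(CCCCCCCOc2ccc(-n3cc(C(=O)Nc4cc(F)cc(F)c4)c(=O)c4ccc(N(C)C)nc43)cc2Cl)CC1` gives 15.4%. The change that turns compound 1 into compound 3 is a group of 8 heavy atoms (6 carbon, 2 nitrogen; one six-membered non-aromatic ring with 2 hetero atoms) in place of a group of 8 heavy atoms (7 carbon, 1 nitrogen; one six-membered non-aromatic ring with 1 hetero atom), on a saturated chain carbon, seven bonds along the chain from an oxygen on an aromatic ring, and this single change brought a number 35 percentage points lower from compound 1 to compound 3 (beyond the scatter). Compound 2 `CC[N+]1(CCCCCCCOc2cc(C)cc(-n3cc(C(=O)Nc4cc(F)cc(F)c4)c(=O)c4ccc(N(C)C)nc43)c2)CCCCC1` is built on a different core; how its core differs from that of compound 1 is not broken down here. In this assay compound 2 gives 86.6%, the highest of the three numbers, with compound 1 the nearest below it and compound 3 the furthest below it, both gaps beyond the usual scatter.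

Compound 4 `Cc1cc(OCCCCCCC[N+]2(C)CCN(C)CC2)cc(-n2cc(C(=O)Nc3cc(F)cc(F)c3)c(=O)c3ccc(N(C)C)nc32)c1` has not yet been measured in this assay. Going by the values given here, it differs from compound 2 by a group of 8 heavy atoms (6 carbon, 2 nitrogen; one six-membered non-aromatic ring with 2 hetero atoms) in place of a group of 8 heavy atoms (7 carbon, 1 nitrogen; one six-membered non-aromatic ring with 1 hetero atom), on a saturated chain carbon, seven bonds along the chain from an oxygen on an aromatic ring, which is the same change, at the same place, as the one from compound 1 to compound 3. For compound 4 the step expected in this assay is a number 36.6 percentage points lower from compound 2 to compound 4 (beyond the scatter), because the same change earlier produced a number 35 percentage points lower from compound 1 to compound 3 (beyond the scatter), and the higher starting point of compound 2 leaves room for a drop of similar size. Compound 4 is therefore estimated at 50%, with the likely range running from 28% to 72%.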

Compound 4, a percentage reported as inhibition, at one concentration (the size of the read-out at that concentration, not a potency): 38.2%
Estimate against measurement, compound 4: 11.8 percentage points above; measured number inside the range.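

In this assay, putting the six-membered non-aromatic ring with 2 hetero atoms in place of the one with 1 hetero atom again brought a large loss, a number 48.4 percentage points lower from compound 2 to compound 4 (beyond the scatter). On the two cores shown, the change carries over in direction and, as far as the scatter allows a comparison, in size: the same change on two cores in this assay, a number 35 percentage points lower (beyond the scatter) from compound 1 to compound 3 and a number 48.4 percentage points lower (beyond the scatter) from compound 2 to compound 4, 13.4 percentage points apart, within the scatter of two such steps
Going by these compounds alone, this rests on only two pairs of compounds, so it does not show that the step would hold on any further core, and it gives no explanation for the loss.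

The compounds shown leave open whether a morpholine or a pyrrolidine ring, at the same place on the saturated chain, would give a similar step on these two cores. They also leave open how an uncharged tertiary amine at the end of the chain, or a longer chain carrying either ring, would read out at this single concentration.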